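Pyridin-3-yl in Place of 3-Methoxyphenyl

A few compounds are considered here, and "the series" means these few. Any claim that something is new, unique, unknown or untested is made for them only; others in the source may bear on it.

Compound 1 `COc1cccc(-c2cc(-c3ccc(F)cc3)c(C#N)c(OC)n2)c1` gives 108 nM in an assay on isolated protein for inhibition of sulfide:quinone oxidoreductase, mitochondrial (Homo sapiens); on this read-out higher numbers stand for weaker inhibition and lower numbers for stronger inhibition. That is the lowest of the three numbers at hand. Compound 2 `COc1nc(-c2ccccc2)cc(-c2ccc(Cl)cc2)c1C#N`, the nearest of the other two, gives 252 nM in this assay, a result that lies beyond the scatter of compound 1. Compound 3 `COc1nc(-c2ccccn2)cc(C(C)(C)C)c1C#N` gives 850 nM in this assay and stands furthest from compound 1. No pair among these three differs in a single place, so each number speaks only for the compound as a whole.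

Compound 4 `COc1nc(-c2cccnc2)cc(-c2ccc(F)cc2)c1C#N` has not yet been measured. It differs from compound 1 in one place: pyridin-3-yl in place of 3-methoxyphenyl on an aromatic carbon. For the measured compounds named here, no measured pair shows this exchange on its own. Compound 2 and compound 3 both sit weaker than compound 1, yet each differs from it in more than one place, so they give only a loose hint about the new group. A moderate loss beyond the scatter is therefore expected, though a result within the scatter would not be surprising. The step of a 2.4-fold higher number from compound 1 to compound 4 (0.38 log units; beyond the scatter) is expected to weaken inhibition somewhat. For compound 4 the estimate is 260 nM, with a range from 80 nM to 850 nM.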

Compound 4, half-maximal inhibitory concentration: 213 nM
For compound 4 the middle estimate is 1.2-fold (0.09 log units) above the measured one; the measured number falls inside the stated range.
By their numbers in this assay, from the lowest: compounds 1, 4 and 2 (each within the scatter of the next, the first and the last beyond it); then compound 3.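

Read on its own, pyridin-3-yl in place of 3-methoxyphenyl on the aromatic carbon next to the ring nitrogen gives a 2.0-fold higher number from compound 1 to compound 4 (0.29 log units; within the scatter) in this assay, the first exchange at this position that can be read without a second difference alongside it. The two groups therefore cannot be told apart on this read-out, even though the entering group has fewer heavy atoms, carries a ring nitrogen and lacks the methoxy group, so that group is not shown to be required at this position for a number in this range. Nothing measured here bears on why the two groups read alike.

The compounds shown leave open whether the location of the ring nitrogen matters, since pyridin-4-yl is absent and the pyridin-2-yl group of compound 3 comes with a tert-butyl group elsewhere on the core, so it cannot be read alone. They also leave open how this position would respond to a saturated ring such as morpholine or to a phenyl ring bearing a carboxylic acid.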